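3,4-Dihydroxyphenyl in Place of 3,5-Dichloro-2-hydroxyphenyl

A few compounds are considered here, and "the series" means these few. Any claim that something is new, unique, unknown or untested is made for them only; others in the source may bear on it.

Among the three compounds measured, compound 3 `O=C(CSc1nnc(-c2ccncc2)o1)N/N=C/c1cc(Cl)cc(Cl)c1O` gives the lowest number in a functional assay on MCF7 cells (Homo sapiens) for cytotoxicity, read by MTT assay, with a stated time of 48 h (on this read-out lower numbers stand for stronger inhibition and higher numbers for weaker inhibition), namely 5920 nM. Compound 1 `Cc1ccc(/C=N/NC(=O)CSc2nnc(-c3ccncc3)o2)cc1` gives 14700 nM and compound 2 `O=C(CSc1nnc(-c2ccncc2)o1)N/N=C/c1ccccc1F` gives 21800 nM. The steps of a 2.5-fold lower number from compound 1 to compound 3 (0.39 log units; beyond the scatter) and a 3.7-fold lower number from compound 2 to compound 3 (0.57 log units; beyond the scatter) show that exchanging the aryl group on the carbon with a double bond to nitrogen shifted the read-out only modestly, while a 1.5-fold higher number from compound 1 to compound 2 (0.17 log units; within the scatter) stayed within the scatter. Compound 4 `O=C(CSc1nnc(-c2ccncc2)o1)N/N=C/c1ccc(O)c(O)c1` carries 3,4-dihydroxyphenyl in place of 3,5-dichloro-2-hydroxyphenyl on a carbon with a double bond to nitrogen. Among the compounds with values here, no measured step removes both chlorines or introduces a second hydroxyl, so those modest aryl exchanges are the only guide. Compound 4 is therefore expected to show a 1.4-fold higher number from compound 3 to compound 4 (0.16 log units; within the scatter). The estimate for compound 4 in this assay is 8500 nM, ranging from 3000 nM to 25000 nM.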

Compound 4, half-maximal inhibitory concentration: 910 nM
Compound 4: the middle estimate sits 9.3-fold (0.97 log units) above what was measured; measured number outside the range, below it.
By their numbers in this assay, from the lowest: compound 4; then compound 3; then compounds 1 and 2 (each within the scatter of the next).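

Within the data shown here, at the carbon with a double bond to nitrogen, 3,4-dihydroxyphenyl gives the first large changes in this assay, with a 16-fold lower number from compound 1 to compound 4 (1.21 log units; beyond the scatter) and a 24-fold lower number from compound 2 to compound 4 (1.38 log units; beyond the scatter), where the earlier aryl exchanges were modest or within the scatter. The same group also improves on the best earlier aryl group, with a 6.5-fold lower number from compound 3 to compound 4 (0.81 log units; beyond the scatter), so this position allows a far lower number than the first compounds suggested. Nothing available explains this gain. The compounds shown leave open whether a single hydroxyl on the phenyl ring would give a similar number. They also leave open whether a methoxy group or an amine could stand in place of either hydroxyl.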